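A few compounds are considered here, and "the series" means these few. Any claim that something is new, unique, unknown or untested is made for them only; others in the source may bear on it.

Of the compounds shown here, two built on the same core have so far been tested in a functional assay on cardiac atrium for agonist activity at histamine H2 receptor (Cavia porcellus); on this read-out higher numbers stand for higher potency (the scale is a negative logarithm) and lower numbers for lower potency. Compound 1 `N/C(=N\CCC(c1ccc(O)cc1)c1ccccn1)NCCCc1c[nH]cn1` gives 6.63 in this assay. Compound 2 `N=C(NCCCc1c[nH]cn1)NCCC(c1ccc(Br)cc1)c1ccccn1` gives 7.48 in this assay, the higher of the two numbers; its nearest neighbour is compound 1, and the gap between them lies beyond the usual scatter of such measurements. Compound 3 `N=C(NCCCc1c[nH]cn1)NCCC(c1ccccn1)c1ccccc1F` has not yet been measured. It differs from compound 2 in one place: 2-fluorophenyl in place of 4-bromophenyl on a saturated chain carbon bound to an aromatic carbon and a saturated chain carbon. Among the compounds with values here, no measured pair in this set shows an exchange of this kind, so the size of the step rests on judgement alone. Compound 3 is expected to come out somewhat lower than compound 2, with a step of about a number 0.48 log units lower from compound 2 to compound 3 (beyond the scatter) in this assay. Compound 3 is therefore estimated at 7 in this assay, within a range from 6.4 to 7.6.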

Compound 3, negative logarithm of the half-maximal effective concentration: 7.46
Estimate against measurement, compound 3: 0.46 log units below, and the stated range covers the measured number.
By their numbers in this assay, from the lowest: compound 1; then compounds 3 and 2 (each within the scatter of the next).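

In this assay, within the data shown here, the exchange gives a number 0.02 log units lower from compound 2 to compound 3 (within the scatter) and is the first step in this set to be read at this position on a saturated chain carbon bound to an aromatic carbon and a saturated chain carbon. The 4-bromophenyl and the 2-fluorophenyl, each with 7 heavy atoms and one six-membered aromatic ring of carbon only, cannot be told apart on this read-out, so this position takes either group without a measurable difference in potency. Nothing shown explains why the two groups match.

The compounds shown leave open whether the halogen is needed at all, since a plain phenyl at this position would test that directly. They also leave open how this position would respond to a phenyl carrying an amine or a carboxylic acid.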